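Swapping 2-Fluorophenyl for 3-Fluorophenyl on the Amide

The source may report more compounds than this note shows. Statements on the series, on what has been measured and on what is new or still open speak of the compounds shown alone.

Compound 1 `CC(C)C(=O)N1CCCn2nc(COc3ccccc3)cc21` gives 59% in a functional assay on HEK293 cells for positive allosteric modulation of metabotropic glutamate receptor 5 (Homo sapiens), read by calcium flux; a lower number here means a smaller maximal response, a higher number a larger maximal response.
Compound 2 `CC(C)(C)C(=O)N1CCCn2nc(COc3ccccc3)cc21` gives 64%.
Compound 3 `O=C(c1ccccc1F)N1CCCn2nc(COc3ccccc3)cc21` gives 62%.

Compound 3 stands second highest of the three, but its step from compound 2 is a number 2 percentage points lower from compound 2 to compound 3 (within the scatter) and the step from compound 1 is a number 3 percentage points higher from compound 1 to compound 3 (within the scatter), so all three values lie together. Compound 4 `O=C(c1cccc(F)c1)N1CCCn2nc(COc3ccccc3)cc21` carries 3-fluorophenyl in place of 2-fluorophenyl on a carbonyl carbon. Among the compounds with values here, no measured step alters a fluorophenyl; the only related steps are those exchanging the whole group on the carbonyl carbon, a number 3 percentage points higher from compound 1 to compound 3 (within the scatter) and a number 2 percentage points lower from compound 2 to compound 3 (within the scatter), plus a number 5 percentage points higher from compound 1 to compound 2 (within the scatter), all within scatter. The expected step of no change at the digits printed from compound 3 to compound 4 (within the scatter) is therefore none beyond the scatter. Compound 4 is estimated at 62%, between 50% and 74%.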

Compound 4, largest response reached (reported as percent of maximum), in percent of the reference or control that the assay uses: 61%
Estimate against measurement, compound 4: 1 percentage points above; the range from low to high includes it.
By their numbers in this assay, from the lowest: compounds 1, 4, 3 and 2 (each within the scatter of the next).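

In this assay, the step of a number 1 percentage points lower from compound 3 to compound 4 (within the scatter) shows that 3-fluorophenyl and 2-fluorophenyl on the carbonyl carbon cannot be told apart. The same holds for the steps of a number 3 percentage points lower from compound 2 to compound 4 (within the scatter) and a number 2 percentage points higher from compound 1 to compound 4 (within the scatter), which exchange tert-butyl and isopropyl for 3-fluorophenyl. Across these four compounds, neither moving the fluorine nor exchanging the whole group separates the values at this position. No available evidence explains this sameness.
Still open, from the compounds shown here alone, is whether an amine or a longer chain on the carbonyl carbon would give a value beyond the scatter.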